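The compounds below may be only part of what the source reports. "The series", "measured", "known", "first", "only" and "open" are said of these compounds alone.

Compound 1 `CC(=O)N[C@@H]1CCC[C@H](C(=O)Nc2cc(-c3cnn4c3CCCC4)c(F)cn2)C1` gives 2.9 in a physicochemical assay for lipophilicity, using the shake flask method, measured as octanol-water partition, at pH 7.4; a lower number here means a more polar compound, a higher number a more lipophilic compound. Compound 2 `CC(=O)N[C@@H]1CCC[C@H](C(=O)Nc2cc(-c3cnc4n3CCCC4)c(Cl)cn2)C1` gives 2.7. Compound 3 `CC(=O)N[C@@H]1CCC[C@H](C(=O)Nc2cc(-c3cnc(C)n3C)c(Cl)cn2)C1` gives 2.2.

Among these three numbers compound 3 stands lowest. Among the compounds with values here, its nearest neighbour is compound 2, reached by the step of a number 0.50 log units lower from compound 2 to compound 3 (beyond the scatter); compound 1 lies further off, as the two values show, with no single-point step joining it to compound 3.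

Compound 4 `CC(=O)N[C@@H]1CCC[C@H](C(=O)Nc2cc(-c3cnn4c3OCCC4)c(Cl)cn2)C1` is the unmeasured compound. It differs from compound 3 in one place: a group of 9 heavy atoms (6 carbon, 2 nitrogen, 1 oxygen; one five-membered aromatic ring with 2 hetero atoms, one six-membered non-aromatic ring with 2 hetero atoms) in place of a group of 7 heavy atoms (5 carbon, 2 nitrogen; one five-membered aromatic ring with 2 hetero atoms), on an aromatic carbon.

Within the data shown here, one measured step bears on this. The step of a number 0.50 log units lower from compound 2 to compound 3 (beyond the scatter) went from a bicyclic group of 9 heavy atoms to a monocyclic group of 7 heavy atoms and lowered the number. Among the measured compounds shown here, the change to compound 4 goes the other way in ring count, so a rise is expected in this assay; but the entering group carries an oxygen in its six-membered non-aromatic ring, and no measured compound shows how that oxygen counts, so the rise is expected to fall short of a full reversal of that step. The expected step is therefore a number 0.40 log units higher from compound 3 to compound 4 (beyond the scatter). For compound 4 the estimate in this assay is 2.6, with a range from 2.1 to 3.1.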

Compound 4, distribution coefficient: 2.6
Estimate against measurement, compound 4: no gap at the digits printed, and the stated range covers the measured number.
By their numbers in this assay, from the lowest: compound 3; then compounds 4, 2 and 1 (each within the scatter of the next).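

In this assay, the second ring at this place, on an aromatic carbon opposite the ring nitrogen, raises the number even with an oxygen in the six-membered non-aromatic ring, with a number 0.40 log units higher from compound 3 to compound 4 (beyond the scatter) as the step from the 1,2-dimethyl-1H-imidazol-5-yl compound. Within the data shown here, the two bicyclic groups cannot be told apart, with a number 0.10 log units lower from compound 2 to compound 4 (within the scatter) as the only reading between them, so among compounds 2, 3 and 4 both bicyclic groups stand above the monocyclic group and none of the three goes against this. Nothing shown explains why the number moves in this way.

Among these compounds, the oxygen's own share stays open: the group in compound 4 also differs from the group in compound 2 in how its rings are joined, and no pair of compounds changes the oxygen alone. On these data alone, how an amine or a hydroxyl group on that six-membered ring would count in this assay is also open, as is whether the same steps would hold with a fluoro group in place of the chloro group.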